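The source may hold more compounds than are shown below. What is called first, only, known or untested is meant among the compounds shown, and "the series" means these compounds.

Of the compounds shown here, two have been measured in an assay on lysate for inhibition of 6-phosphofructo-2-kinase/fructose-2,6-bisphosphatase 3 (Homo sapiens), with stated times of 0.5 min and 45 min; on this read-out higher numbers stand for weaker inhibition and lower numbers for stronger inhibition. Compound 1 `Cn1ccc2ccc(-c3cc(Nc4ccccc4S(N)(=O)=O)cc4nccnc34)cc21` gives 37600 nM in this assay. Compound 2 `CC(=O)N1CCC(NC(=O)c2ccncc2Nc2cc(-c3ccc4ccn(C)c4c3)c3nccnc3c2)CC1` gives 31300 nM in this assay; this is the lower of the two numbers, but the gap to compound 1 lies within the scatter, so no order can be read between them, and both sit in the weak range.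

Compound 3 `CC(=O)N1CCOC(CNC(=O)c2ccncc2Nc2cc(-c3ccc4ccn(C)c4c3)c3nccnc3c2)C1` has not yet been measured. It differs from compound 2 in one place: (4-acetylmorpholin-2-yl)methyl in place of 1-acetylpiperidin-4-yl on an amide-type nitrogen. Both the leaving and the entering group carry the acetyl; the change reshapes the substituent on the amide-type nitrogen while leaving the shared core untouched. For the measured compounds named here, no measured pair of the series shows this change, so its size cannot be read from the data. The expected step is one within the scatter, a 1.1-fold higher number from compound 2 to compound 3 (0.05 log units; within the scatter), with no direction favoured. Compound 3 is therefore expected to give about 35000 nM in this assay, with a likely range from 12000 nM to 100000 nM.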

Compound 3, half-maximal inhibitory concentration: > 100000 nM
Compound 3 was reported as a limit; the forecaster's own chance of this, stated with the estimate: 15%; middle value at least 2.8-fold (0.45 log units) from the limit.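

In this assay compound 3 stands only as a limit, > 100000 nM, and not as a number. The substituent on the amide-type nitrogen is thus shown not to be a silent place: with the shared core untouched, (4-acetylmorpholin-2-yl)methyl in place of 1-acetylpiperidin-4-yl gives an at least 3.1-fold higher number from compound 2 to compound 3 (0.50 log units; beyond the scatter), the only step read in the series so far. The true size of this step stays unbounded on the upper side, and it rests on a single reported limit: the limit of > 100000 nM in this assay, at which 1 of the 3 values shown sits.

From the compounds shown here alone, this one pair changes the ring and adds the methyl link at once, so the share of each in the step stays open. Also open, going by these compounds, is how a free amine or a carboxylic acid in place of the acetyl on either ring would read in this assay.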